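A few compounds are considered here, and "the series" means these few. Any claim that something is new, unique, unknown or untested is made for them only; others in the source may bear on it.

Measured in an in vivo ADME assay on the whole organism (plasma, strain Sprague-Dawley) for pharmacokinetics, with Rattus norvegicus as the target; on this read-out higher numbers stand for fast clearance and lower numbers for slow clearance:
- Compound 1 `CN[C@@H](C)c1ccc(N2CC[C@H](NS(=O)(=O)c3ccc4cc(Cl)ccc4c3)C2=O)c(F)c1`: 1.6 mL/min/kg
- Compound 2 `O=C1[C@@H](NS(=O)(=O)/C=C/c2ccc(Cl)s2)CCN1c1ccc(C2CCCN2)cc1F`: 2.8 mL/min/kg

Compound 2, at 2.8 mL/min/kg, lies within the usual scatter of compound 1, at 1.6 mL/min/kg. Compound 3 `O=C1[C@@H](NS(=O)(=O)c2ccc3cc(Cl)ccc3c2)CCN1c1ccc(C2CCCN2)cc1F` has 6-chloronaphthalen-2-yl in place of 2-(5-chlorothiophen-2-yl)ethenyl on a sulfonyl sulfur. Going by the values given here, no measured pair differs in only one place, so the size of this step cannot be read directly from the data. Compound 1 carries the same 6-chloronaphthalen-2-yl group on a different remainder and gives 1.6 mL/min/kg, so no change beyond the scatter is expected. The expected step of a 1.4-fold lower number from compound 2 to compound 3 (0.15 log units; within the scatter) stays within that scatter. For compound 3 the estimated clearance is 2 mL/min/kg, with an expected range of 0.9 mL/min/kg to 4.5 mL/min/kg.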

Compound 3, clearance: 2.7 mL/min/kg
For compound 3 the middle estimate is 1.4-fold (0.13 log units) below the measured one; measured number inside the range.
By their numbers in this assay, from the lowest: compounds 1, 3 and 2 (each within the scatter of the next).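

In this assay the change on the sulfonyl sulfur gives a 1.0-fold lower number from compound 2 to compound 3 (0.02 log units; within the scatter) and so shows that 6-chloronaphthalen-2-yl and 2-(5-chlorothiophen-2-yl)ethenyl cannot be told apart at this position. The change on the aromatic carbon gives a 1.7-fold higher number from compound 1 to compound 3 (0.23 log units; within the scatter) and so pyrrolidin-2-yl and 1-(methylamino)ethyl cannot be told apart there either. No measured evidence bears on why these swaps leave clearance within the scatter.

On these data alone, whether a carboxylic acid or a simple methyl on the sulfonyl sulfur would also leave clearance within the scatter remains open.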